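This account rests on a few compounds, and the source may have more. Where it says the series, first, only, none or still open, it means among the compounds named here.

Compound 1 (`Cc1ccccc1Nc1nc(NC2CC2)ncc1Cl`), compound 2 (`Cc1ccccc1Nc1nc(NC2CCCCC2)ncc1Cl`) and compound 3 (`Cc1ccccc1Nc1nc(NCc2ccco2)ncc1Cl`) share one core and differ only in the group on a nitrogen on an aromatic ring. In an ADME assay on L02 cells (Homo sapiens) for inhibition, read by CCK-8 assay, with a stated time of 48 h (on this read-out higher numbers stand for weaker inhibition of growth and lower numbers for stronger inhibition of growth), compound 1 gives > 100000 nM, which is a limit of the assay. Compound 2 gives > 100000 nM, also a limit. Compound 3 gives > 100000 nM, again a limit. Compound 3 therefore has no exact number and stands with the other two at the limit of > 100000 nM in this assay, at which 3 of the 3 values shown sit.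

Compound 4 (`Cc1ccccc1Nc1nc(Nc2ccccn2)ncc1Cl`) carries pyridin-2-yl in place of (furan-2-yl)methyl on that nitrogen: pyridin-2-yl in place of (furan-2-yl)methyl on a nitrogen on an aromatic ring. Two measured swaps on the same nitrogen bear on this change, a step that the two limits leave unreadable from compound 1 to compound 3 and a step that the two limits leave unreadable from compound 2 to compound 3. Neither gives a size to carry over, so no step beyond the scatter is expected, and another limit is the likeliest report. The expected change is a number no higher from compound 3 to compound 4 (the limit leaves the size open). In this assay the estimate for compound 4 is 100000 nM, with an expected range from 30000 nM to 300000 nM.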

Compound 4, concentration for 50% growth inhibition: 6150 nM
Beside the measured number, compound 4's estimate is 16-fold (1.21 log units) above it; measured number below the stated range.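

The steps among compound 1, compound 2 and compound 3 cannot be read, and all three share one limit: the limit of > 100000 nM in this assay, at which 3 of the 4 values shown sit. Compound 4 shows that the group on this nitrogen can still move the number in this assay toward stronger inhibition of growth, with pyridin-2-yl giving an at least 16-fold lower number from compound 3 to compound 4 (1.21 log units; beyond the scatter) and an at least 16-fold lower number from compound 2 to compound 4 (1.21 log units; beyond the scatter) and also (an at least 16-fold lower number from compound 1 to compound 4 (1.21 log units; beyond the scatter)). The count of heavy atoms is the same in the group that leaves compound 3 and the group that enters compound 4, and compound 4 alone of the four carries an aromatic ring directly on that nitrogen.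

From the compounds shown here alone, what remains open is whether this step goes with the ring nitrogen of pyridin-2-yl or with any aromatic ring set directly on that nitrogen. A plain phenyl or a pyridin-3-yl group in the same place would separate the two.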